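Trifluoromethoxy in place of nitro on compound 3

The source may hold more compounds than are shown below. What is called first, only, known or untested is meant among the compounds shown, and "the series" means these compounds.

In a functional assay on A549 cells (Homo sapiens) for inhibition, read by sulforhodamine B assay, with a stated time of 74 h (on this read-out lower numbers stand for stronger inhibition and higher numbers for weaker inhibition), compound 1 `Cc1ccc(S(=O)(=O)N2C(=O)COC23C=CC(=O)C=C3)cc1` gives 110 nM as a measured number. Compound 2 `CS(=O)(=O)N1C(=O)COC12C=CC(=O)C=C2` reads > 10000 nM and this is a limit of the assay. Compound 3 `O=C1C=CC2(C=C1)OCC(=O)N2S(=O)(=O)c1ccc([N+](=O)[O-])cc1` reads > 10000 nM and this too is only a limit, so compound 3 stands at the limit of > 10000 nM in this assay, at which 2 of the 3 values shown sit, without a number. Compound 4 `O=C1C=CC2(C=C1)OCC(=O)N2S(=O)(=O)c1ccc(OC(F)(F)F)cc1` carries trifluoromethoxy in place of nitro on an aromatic carbon and remains unmeasured. Among the measured compounds shown here, two measured steps bear on this change, both large. Nitro in place of methyl gave an at least 90-fold higher number from compound 1 to compound 3 (1.95 log units; beyond the scatter) at this same place, and methyl in place of 4-methylphenyl gave an at least 90-fold higher number from compound 1 to compound 2 (1.95 log units; beyond the scatter) on the sulfonyl sulfur. With nitro gone, a large step toward a lower number is expected, estimated as an at least 20-fold lower number from compound 3 to compound 4 (1.30 log units; beyond the scatter) in size. For compound 4 the estimate is 500 nM with an expected range from 80 nM to 5000 nM in this assay.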

Compound 4, half-maximal inhibitory concentration: 40 nM
Estimate against measurement, compound 4: 13-fold (1.10 log units) above; measured number below the stated range.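

In this assay, this aromatic position, para to a large group, is not limited to methyl: an at least 250-fold lower number from compound 3 to compound 4 (2.39 log units; beyond the scatter), so the group here alone can separate a measurable number from none. Trifluoromethoxy also improves on methyl, with a 2.8-fold lower number from compound 1 to compound 4 (0.44 log units; beyond the scatter). The first of these steps starts from a limit of the assay, not from a number: the limit of > 10000 nM in this assay, at which 2 of the 4 values shown sit.

On these data alone, whether an amine, a carboxylic acid or methoxy at this place would read like trifluoromethoxy or like nitro stays open. The compounds shown also do not tell what in trifluoromethoxy sets it apart from nitro.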